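Ortho-halogen hydrazones of a shared core, antiproliferative notes

The source may hold more compounds than are shown below. What is called first, only, known or untested is meant among the compounds shown, and "the series" means these compounds.

Three members of the series have numbers in a functional assay on MGC-803 cells (Homo sapiens) for antiproliferative activity, read by MTT assay, with a stated time of 72 h; a lower number here means a stronger inhibitor, a higher number a weaker inhibitor. Compound 1 `CCCSc1nc(N/N=C(\C)c2ccc(OC)cc2)c2nnn(Cc3ccccc3)c2n1` gives 44300 nM in this assay, and compound 3 `CCCSc1nc(N/N=C(\C)c2ccccc2O)c2nnn(Cc3ccco3)c2n1` gives 4760 nM. Going by the values given here, compound 2 `CCCSc1nc(N/N=C/c2ccccc2F)c2nnn(Cc3ccccc3)c2n1` returns only a limit in this assay, > 64000 nM, so it stands at the edge of the measurable range, as recorded by the limit of > 64000 nM in this assay, at which 1 of the 3 values shown sits; no single-change step between measured compounds exists here. The next member, compound 4 `CCCSc1nc(N/N=C/c2ccccc2Cl)c2nnn(Cc3ccccc3)c2n1`, differs from compound 2 by chloro in place of fluoro on an aromatic carbon. Among the compounds with values here, no measured step of this kind is available; the change is expected to move this assay by little, a step from compound 2 to compound 4 of an at least 1.0-fold lower number from compound 2 to compound 4 (0.02 log units; that floor lies within the scatter) that stays within scatter. Compound 4 is accordingly estimated at 60000 nM in this assay, within a range of 20000 nM to 150000 nM, with a fair chance that it too returns only a limit.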

Compound 4, half-maximal inhibitory concentration: 10900 nM
For compound 4 the middle estimate is 5.5-fold (0.74 log units) above the measured one; measured number below the stated range.
By their numbers in this assay, from the lowest: compound 3; then compound 4; then compound 1. At a limit, above all of these: compound 2.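

Chloro in place of fluoro at this place, on an aromatic carbon ortho to a large group, is the first single change that can be read in the series, and it is not neutral in this assay: an at least 5.8-fold lower number from compound 2 to compound 4 (0.76 log units; beyond the scatter). Compound 4 has a measured value at this position, whereas compound 2 has only a limit. The step is therefore a floor, not a full size: the limit of > 64000 nM in this assay, at which 1 of the 4 values shown sits.

From the compounds shown here alone, whether bromo or an amine at this place would give a lower or higher number stays open. Going by these compounds alone, with only this one pair, it is also unknown whether the change would act alike elsewhere.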